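A few compounds are considered here, and "the series" means these few. Any claim that something is new, unique, unknown or untested is made for them only; others in the source may bear on it.

The study concerns two chalcone-like compounds that share one core, both tested in a functional assay on K562 cells (Homo sapiens) for antiproliferative activity, read by MTT assay, with a stated time of 24 h; on this read-out lower numbers stand for stronger inhibition and higher numbers for weaker inhibition. Compound 1, `COc1ccc(C(=O)/C=C/c2ccc(-c3ccccc3)cc2)c2c1C=CC(C)(C)O2`, gives in this assay only a limit of the assay rather than a number, > 10000 nM. Compound 2, `COc1ccc(/C=C/C(=O)c2ccc(OC)c3c2OC(C)(C)C=C3)cn1`, likewise gives in this assay only a limit, > 10000 nM. Compound 2 therefore stands at the limit of > 10000 nM in this assay, at which 2 of the 2 values shown sit; the numbers shown do not separate it from compound 1, and how far below that limit either compound might actually lie is not known.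

Compound 3, `COc1ccc(C(=O)/C=C/c2ccccc2Cl)c2c1C=CC(C)(C)O2`, has not yet been measured. It differs from compound 2 in one place: 2-chlorophenyl in place of 6-methoxypyridin-3-yl on a double-bonded chain carbon bound to a double-bonded chain carbon. For the measured compounds named here, no step between two measured compounds is available, so the size of this change cannot be read from any measured pair. Because compound 2 sits at > 10000 nM, and the change exchanges one aromatic ring for another, the expected step is a step that the limit leaves unreadable from compound 2 to compound 3, most likely none beyond the scatter, with a considerable chance that only a limit is reported again. Compound 3 is therefore estimated at 15000 nM in this assay, within a range from 4000 nM to 60000 nM.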

Compound 3, half-maximal inhibitory concentration: > 10000 nM
Compound 3 ended at the assay's limit (the forecaster's own chance of this, stated with the estimate: 65%); the middle value does not contradict the limit.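

No step can be read between compound 2 and compound 3, as each gives only a limit of the assay and not a number. All three compounds stand at the same place: the limit of > 10000 nM in this assay, at which 3 of the 3 values shown sit. They leave open how strongly any of them acts on these cells, and which change to the shared core would yield a measurable value.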